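Swapping a methylated indole for a short dienyl chain

The source may report more compounds than this note shows. Statements on the series, on what has been measured and on what is new or still open speak of the compounds shown alone.

Compound 1, `CCCCCCCCCCCCNC(=O)[C@@H](NC(=O)c1nccc2ccccc12)[C@@H](C)O`, gives 65700 nM in a functional assay on HepG2 cells (Homo sapiens) for cytotoxicity, read by MTT assay, with a stated time of 48 h; on this read-out lower numbers stand for stronger inhibition and higher numbers for weaker inhibition. Compound 2, `CCCCCCCCCCCCNC(=O)[C@@H](NC(=O)c1cc2ccccc2[nH]1)[C@@H](C)O`, gives 12000 nM in this assay. Compound 3, `CCCCCCCCCCCCNC(=O)[C@@H](NC(=O)c1cc2ccccc2n1C)[C@@H](C)O`, is reported in this assay only as a limit, > 200000 nM.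

Compound 3 stands at the limit of > 200000 nM in this assay, at which 1 of the 3 values shown sits, weaker than both others: an at least 3.0-fold higher number from compound 1 to compound 3 (0.48 log units; beyond the scatter) and an at least 16-fold higher number from compound 2 to compound 3 (1.22 log units; beyond the scatter). Compound 4, `C/C=C/C=C/C(=O)N[C@H](C(=O)NCCCCCCCCCCCC)[C@@H](C)O`, differs from compound 3 by penta-1,3-dien-1-yl in place of 1-methyl-1H-indol-2-yl on a carbonyl carbon. The measured steps speak only about the aromatic groups; the two reaching compound 3 show the 1-methyl-1H-indol-2-yl group as the worst of the three, and none concerns an open dienyl chain. Replacing that group is therefore expected to bring the number back down somewhat, with wide uncertainty, as an at least 2.5-fold lower number from compound 3 to compound 4 (0.39 log units; beyond the scatter). Compound 4 is estimated at 80000 nM, between 20000 nM and 300000 nM.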

Compound 4, half-maximal inhibitory concentration: > 400000 nM
Compound 4 gave a limit, no number; the forecaster's own chance of this, stated with the estimate: 35%; middle value at least 5.0-fold (0.69 log units) away from the limit.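

In this assay, the open penta-1,3-dien-1-yl chain on this carbonyl carbon brings no recovery, giving an at least 33-fold higher number from compound 2 to compound 4 (1.52 log units; beyond the scatter) and an at least 6.0-fold higher number from compound 1 to compound 4 (0.78 log units; beyond the scatter). Among the compounds shown, the two with the better numbers, compound 1 and compound 2, both carry fused aromatic groups here, but compound 3 carries one too and goes against any simple rule. Compound 3 and compound 4 are both reported only as limits, so the step between them cannot be read: the limit of > 400000 nM in this assay, at which 1 of the 4 values shown sits.

From the compounds shown here alone, whether a plain phenyl ring or a saturated pentyl chain at this place would come closer to compound 2 remains open.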